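Extending an Ether Chain on an Inactive Pair

A few compounds are considered here, and "the series" means these few. Any claim that something is new, unique, unknown or untested is made for them only; others in the source may bear on it.

Compound 1: `O=c1cc(CC(O)(COCc2ccccc2)COCc2ccccc2)[nH]c(=O)[nH]1` — > 100000 nM (a limit)
Compound 2: `COCn1c(CC(O)(COCc2ccccc2)COCc2ccccc2)cc(=O)[nH]c1=O` — > 100000 nM (a limit)

Both measured compounds were tested in a functional assay on SW-620 cells (Homo sapiens) for antiproliferative activity, read by MTT assay, with a stated time of 72 h; a lower number here means a stronger inhibitor, a higher number a weaker inhibitor. Compound 1 `O=c1cc(CC(O)(COCc2ccccc2)COCc2ccccc2)[nH]c(=O)[nH]1` reaches only the limit of the assay, > 100000 nM. Compound 2 `COCn1c(CC(O)(COCc2ccccc2)COCc2ccccc2)cc(=O)[nH]c1=O` likewise gives only a limit, > 100000 nM. The step that the two limits leave unreadable from compound 1 to compound 2, methoxymethyl in place of hydrogen on an aromatic nitrogen, cannot be read because of the limit of > 100000 nM in this assay, at which 2 of the 2 values shown sit. Compound 3 `C[Si](C)(C)CCOCn1c(CC(O)(COCc2ccccc2)COCc2ccccc2)cc(=O)[nH]c1=O` differs from compound 2 by a group of 5 heavy atoms (4 carbon, 1 silicon; no ring) in place of a hydrogen atom, on a saturated chain carbon bound to an oxygen on a saturated carbon. Among the compounds with values here, the single measured step touches the same part of the molecule, but its size is unknown and both values shown are limits, so neither a direction nor a size can be drawn from it. Compound 3 is therefore expected to remain at the limit, the expected step being a number no higher from compound 2 to compound 3 (the limit leaves the size open). Compound 3 is estimated at 100000 nM, within a range of 30000 nM to 300000 nM.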

Compound 3, half-maximal inhibitory concentration: > 100000 nM
Compound 3: only a limit was reported (the forecaster's own chance of this, stated with the estimate: 85%); the middle value lies on the limit itself.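

Within the data shown here, no step among compound 1, compound 2 and compound 3 can be read, because all three stop at the same limit: the limit of > 100000 nM in this assay, at which 3 of the 3 values shown sit. On these data alone, whether methoxymethyl or the larger silicon-bearing group on the aromatic nitrogen changes the activity at all, and in which direction, stays open.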